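Shortening One Arm of Compound 2

The source may hold more compounds than are shown below. What is called first, only, known or untested is meant among the compounds shown, and "the series" means these compounds.

Of the compounds shown here, two have been measured in a functional assay on HL-60 cells (Homo sapiens) for activation, read by annexin V staining, with a stated time of 48 h; a higher number here means that more compound is needed for the effect, a lower number that less compound is needed. Compound 1 `CC1(C)OC(=O)C2(C(=O)O1)[C@@H](c1ccc(-c3ccc(-c4ccc(O)cc4)cc3)cc1)CC(=O)C[C@H]2c1ccccc1` gives 32000 nM. Compound 2 `Oc1ccc(-c2ccc(-c3cc(O)cc(O)c3)cc2)cc1` gives 25000 nM, the lowest of the two numbers, though its gap to compound 1 lies within the scatter. For the measured compounds named here, compound 3 `OCc1ccc(-c2cc(O)cc(O)c2)cc1` has not been measured; it differs from compound 2 in one place: hydroxymethyl in place of 4-hydroxyphenyl on an aromatic carbon No measured pair shows a step of this kind, so its size is uncertain. Compound 3 is expected to give a higher number, a step of a 2.4-fold higher number from compound 2 to compound 3 (0.38 log units; beyond the scatter) beyond the scatter. Compound 3 is estimated at 60000 nM, within a range from 20000 nM to 200000 nM.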

Compound 3, concentration for half-maximal activity: > 80000 nM
Compound 3: only a limit was reported (the forecaster's own chance of this, stated with the estimate: 30%); middle value at least 1.3-fold (0.12 log units) away from the limit.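

In this assay, this position is not indifferent to the change: putting hydroxymethyl in place of 4-hydroxyphenyl gives an at least 3.2-fold higher number from compound 2 to compound 3 (0.50 log units; beyond the scatter). For compound 3, the > 80000 nM is a limit of the assay and not a number. The swap removes an aromatic ring while the counts of hydrogen-bond donors and acceptors stay the same, so this arm matters beyond those counts.

The compounds shown cannot separate the loss of the ring from the loss of length. As far as these compounds go, it remains open how a longer chain ending in a hydroxyl, an amine or a carboxylic acid would behave here.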